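Moving the hydroxy group from 3-hydroxyphenyl to 4-hydroxyphenyl

The compounds below may be only part of what the source reports. "The series", "measured", "known", "first", "only" and "open" are said of these compounds alone.

In a functional assay on RAW264.7 cells (Mus musculus) for inhibition, read by fluorescence, with stated times of 1 h, 24 h and 30 min (on this read-out lower numbers stand for stronger inhibition and higher numbers for weaker inhibition), compound 1 `O=C(/C=C/c1cccc(OC(F)(F)F)c1)c1ccccc1` gives > 10000 nM, which is a limit of the assay. Compound 2 `O=C(/C=C/c1cccc(OC(F)(F)F)c1)c1cccc(O)c1` gives > 10000 nM, also a limit, so it has no exact position on the scale. The evidence so far is the limit of > 10000 nM in this assay, at which 2 of the 2 values shown sit. Compound 3 `O=C(/C=C/c1cccc(OC(F)(F)F)c1)c1ccc(O)cc1` differs from compound 2 by 4-hydroxyphenyl in place of 3-hydroxyphenyl on a carbonyl carbon. Among the measured compounds shown here, the only measured step is a step that the two limits leave unreadable from compound 1 to compound 2. It gives no size to carry over, so no step beyond the scatter is expected in this assay, in either direction. The estimated change is a number no higher from compound 2 to compound 3 (the limit leaves the size open). For compound 3 the expected value is 10000 nM, with an estimated range of 3000 nM to 30000 nM.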

Compound 3, half-maximal inhibitory concentration: > 10000 nM
Compound 3: a limit, no number; the forecaster's own chance of this, stated with the estimate: 65%; the middle value sits exactly at the limit.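

Among the compounds shown here, compound 3 gives > 10000 nM, a limit and not a number, so no step among compound 1, compound 2 and compound 3 can be read. The compounds shown leave open whether their inhibition differs at all, and which change to the shared core would give a readable value: the limit of > 10000 nM in this assay, at which 3 of the 3 values shown sit.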